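The source may hold more compounds than are shown below. What is called first, only, known or untested is meant among the compounds shown, and "the series" means these compounds.

Measured in a functional assay on SMMC-7721 cells (Homo sapiens) for inhibition, read by MTT assay, with a stated time of 72 h, tested at 25 uM; a higher number here means more inhibition at the concentration tested (going by the name of the read-out), a lower number less inhibition:
compound 1, `Cc1nn(C)c(Oc2ccc(OC(F)(F)F)cc2)c1/C=N\OCc1c(Cl)c(-c2ccc(F)cc2)nn1C`, gives 80%
compound 2, `COc1ccc(Oc2c(/C=N\OCc3c(Cl)c(-c4ccc(Cl)cc4)nn3C)c(C)nn2C)cc1`, gives 80%

Compound 2 stands level with compound 1 at the digits reported; the gap between the two readings lies within the usual scatter of this assay, so no order between them can be read from these numbers. Among the measured compounds shown here, no pair of measured compounds differs in a single place, so the size of any one-point step in this assay has not been observed directly in this set.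

Compound 3, `Cc1nn(C)c(Oc2ccc(OC(F)(F)F)cc2)c1/C=N\OCc1c(Cl)c(-c2ccc(Cl)cc2)nn1C`, is not yet measured. Relative to compound 2 the change is trifluoromethyl in place of methyl on an oxygen on an aromatic ring. The group that enters is already carried by compound 1, whose reading in this assay is 80%, the same as compound 2 at the digits reported, and compound 3 carries the chlorophenyl of compound 2. On that basis no step beyond the scatter is expected: the estimated change is no change at the digits printed from compound 2 to compound 3 (within the scatter). For compound 3 the expected inhibition in this assay is 80%, with a likely range from 68% to 90%.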

Compound 3, a percentage reported as inhibition, at one concentration (the size of the read-out at that concentration, not a potency): 80%
Compound 3: middle estimate and measured number agree at the digits printed; the measured number falls inside the stated range.
By their numbers in this assay, from the lowest: compounds 1, 2 and 3 (each within the scatter of the next).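

In this assay, the change from methoxy to trifluoromethoxy on the aromatic ring can now be read directly, with the rest of the molecule held constant: no change at the digits printed from compound 2 to compound 3 (within the scatter). Among the compounds shown here, the same compound also gives the first reading for chloro in place of fluoro on an aromatic carbon, with the 4-(trifluoromethoxy)phenoxy group held constant: no change at the digits printed from compound 1 to compound 3 (within the scatter). Neither single change therefore produces a step beyond the scatter in this set, and no supporting measurement bears on the reason for this.

From the compounds shown here alone, a percentage at one concentration is not a potency, so it remains open whether these three compounds would separate in a full concentration series. Also open, going by these compounds, is how the reading responds at the oxygen-linked position to a longer chain such as butoxy, or on the aromatic ring to an amine or a carboxylic acid in place of trifluoromethoxy.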